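Hydroxycarbamoyl end group on a shorter chain

The compounds below may be only part of what the source reports. "The series", "measured", "known", "first", "only" and "open" are said of these compounds alone.

Values in a functional assay on MCF7 cells (Homo sapiens) for inhibition, read by MTT assay, with a stated time of 72 h; on this read-out lower numbers stand for stronger inhibition and higher numbers for weaker inhibition
- compound 1 `CNC(=O)CCCCCCCn1nc(-c2cnc3[nH]ccc3c2)c2c(N)ncnc21` gives 7570 nM
- compound 2 `Nc1ncnc2c1c(-c1cnc3[nH]ccc3c1)nn2CC(=O)NO` gives > 150000 nM (a limit)
- compound 3 `Nc1ncnc2c1c(-c1cnc3[nH]ccc3c1)nn2CCCCCCCCC(=O)NO` gives 24700 nM

Compound 1 gives the lowest number of the series (7570 nM) and compound 3 the nearest one (24700 nM). Compound 2 gives > 150000 nM as its reading, and this is a limit of the assay, not a number.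

Compound 4 `Nc1ncnc2c1c(-c1cnc3[nH]ccc3c1)nn2CCCCCCC(=O)NO` differs from compound 1 by hydroxycarbamoyl in place of (methylcarbamoyl)methyl on a saturated chain carbon, six bonds along the chain from an aromatic nitrogen.

Within the data shown here, two measured steps bear on this change. The closer one is modest (a 3.3-fold higher number from compound 1 to compound 3 (0.51 log units; beyond the scatter)) and carries the same end group on a longer chain, so compound 3 is the main guide. The other is large (an at least 19-fold higher number from compound 1 to compound 2 (1.29 log units; beyond the scatter)), but the chain of compound 2 is far shorter than that of compound 4, so it weighs less. A modest move to a higher number in this assay is therefore expected, not a large one. The estimated change is a 2.1-fold higher number from compound 1 to compound 4 (0.33 log units; beyond the scatter) (an expectation only). For compound 4 the expected value is 16000 nM (estimated range 5000 nM to 50000 nM).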

Compound 4, half-maximal inhibitory concentration: 19800 nM
Estimate against measurement, compound 4: 1.2-fold (0.09 log units) below; the measured number falls inside the stated range.
By their numbers in this assay, from the lowest: compound 1; then compounds 4 and 3 (each within the scatter of the next). At a limit, above all of these: compound 2.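

In this assay, the hydroxycarbamoyl end group at this place on the chain gives a 2.6-fold higher number from compound 1 to compound 4 (0.42 log units; beyond the scatter), a modest step in the same direction as the one already seen on the longer chain. Between the two longer hydroxycarbamoyl chains the step is a 1.2-fold lower number from compound 3 to compound 4 (0.10 log units; within the scatter), so chain length does not separate these two compounds. Only the very short chain of compound 2 stands apart, with an at least 7.5-fold lower number from compound 2 to compound 4 (0.87 log units; beyond the scatter), and that step starts from a limit of the assay, not a number: the limit of > 150000 nM in this assay, at which 1 of the 4 values shown sits.

As far as these compounds go, the step from compound 1 alters the end group and the chain length together, so the share of each stays open. Also open, from the compounds shown here alone, is how a carboxylic acid at the end of the chain, or a chain of intermediate length between those of compound 2 and compound 4, would read in this assay.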